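The source may report more compounds than this note shows. Statements on the series, on what has been measured and on what is new or still open speak of the compounds shown alone.

Compound 1 `Cc1nn(-c2ncnc3nc[nH]c23)c2c1C(OCC(=O)c1ccc(F)cc1)CC(=O)N2`: 3 nM in a functional assay on HEK293 cells for agonist activity at G-protein coupled receptor 39 (Homo sapiens), read by scintillation proximity assay and inositol phosphate accumulation, with a stated time of 75 min, in the presence of a further agent that is not named here; on this read-out lower numbers stand for an effect already at smaller amounts and higher numbers for an effect only at larger amounts of compound
Compound 2 `Cc1nn(-c2ncnc3nc[nH]c23)c2c1C(OCc1ccccc1F)CC(=O)N2`: 4 nM in this assay
Compound 3 `Cc1nn(-c2ncnc3nc[nH]c23)c2c1C(OCc1ccc(F)cc1)CC(=O)N2`: 1 nM in this assay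

Compound 3 holds the lowest of the three numbers. Measured against the others, a 3.0-fold lower number from compound 1 to compound 3 (0.48 log units; beyond the scatter) and a 4.0-fold lower number from compound 2 to compound 3 (0.60 log units; beyond the scatter); both steps lie beyond the scatter, so compound 3 is the most potent of the three measured compounds in this assay.

Compound 4 `COc1ccc(CCOC2CC(=O)Nc3c2c(C)nn3-c2ncnc3nc[nH]c23)cc1` differs from compound 3 in a single place: 4-methoxybenzyl in place of 4-fluorophenyl on a saturated chain carbon bound to an oxygen on a saturated carbon. All three measured steps concern this same place. Two of them, a 3.0-fold lower number from compound 1 to compound 3 (0.48 log units; beyond the scatter) and a 4.0-fold lower number from compound 2 to compound 3 (0.60 log units; beyond the scatter), bring 4-fluorophenyl in and lower the number modestly; the third, a 1.3-fold higher number from compound 1 to compound 2 (0.12 log units; within the scatter), swaps two other groups and stays within the scatter. None of them puts 4-methoxybenzyl at this place, so the measured steps show only the range this position has covered so far, which is modest in both directions. The change from 4-fluorophenyl to a larger group is expected to cost some potency, and the step is estimated as a 4.0-fold higher number from compound 3 to compound 4 (0.60 log units; beyond the scatter). Compound 4 is therefore expected to give about 4 nM in this assay, with a likely range from 1 nM to 15 nM.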

Compound 4, half-maximal effective concentration: 2 nM
Compound 4: middle estimate off by 2.0-fold (0.30 log units), on the high side; measured number inside the range.
By their numbers in this assay, from the lowest: compounds 3, 4, 1 and 2 (each within the scatter of the next, the first and the last beyond it).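

In this assay, among the compounds shown here, the earlier compounds all carried a fluorine on the ring of this side chain, and compound 4 shows that a ring bearing a methoxy group and no fluorine also fits here. Replacing 4-fluorobenzyl with the longer 2-(4-methoxyphenyl)ethyl gives a 2.0-fold higher number from compound 3 to compound 4 (0.30 log units; within the scatter) and so leaves the number inside the usual variation between repeated measurements, even though the group that enters is the larger one. Against the other two compounds, the change gives a 2.0-fold lower number from compound 2 to compound 4 (0.30 log units; within the scatter) and a 1.5-fold lower number from compound 1 to compound 4 (0.18 log units; within the scatter) so compound 4 cannot be told apart from any of the three, and nothing measured here explains why this place accepts such different groups.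

On these data alone, all four compounds end this side chain in a six-membered aromatic ring of carbon only, so it remains open whether that ring is needed at all, for example whether a plain alkyl chain would serve as well. As far as these compounds go, it is equally open how the number would respond to an amine or a carboxylic acid at the end of the chain, or to a longer chain such as 3-phenylpropyl.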